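The compounds below may be only part of what the source reports. "The series", "measured", "known", "first", "only" and "open" are said of these compounds alone.

Compound 1 `Cc1ccc(C2=NN(C3=NC(c4ccccc4)CS3)C(c3ccc4ccccc4c3)C2)cc1C` gives 950 nM in a functional assay on HeLa cells (Homo sapiens) for inhibition, read by CCK-8 assay, with a stated time of 48 h; on this read-out lower numbers stand for stronger inhibition and higher numbers for weaker inhibition. Compound 2 `Cc1ccc(C2=NN(C3=NC(=O)CS3)C(c3ccc4ccccc4c3)C2)cc1C` gives 860 nM. Compound 3 `Brc1ccc(C2=NN(C3=NC(c4ccccc4)CS3)C(c3cccc4ccccc34)C2)cc1` gives 6650 nM.

Compound 1 and compound 2 differ in one place, (a group of 6 heavy atoms (3 carbon, 1 nitrogen, 1 oxygen, 1 sulfur; one five-membered non-aromatic ring with 2 hetero atoms) in place of a group of 11 heavy atoms (9 carbon, 1 nitrogen, 1 sulfur; one five-membered non-aromatic ring with 2 hetero atoms, one six-membered aromatic ring of carbon only), on an amine nitrogen in a ring), and this change made a 1.1-fold lower number from compound 1 to compound 2 (0.04 log units; within the scatter). Compound 3 gives the highest number of the three, and the difference between its core and the core of compound 1 is not broken down here. Compound 4 `O=C1CSC(N2N=C(c3ccc(Br)cc3)CC2c2cccc3ccccc23)=N1` has not yet been measured; it arises from compound 3 by the same kind of change, (a group of 6 heavy atoms (3 carbon, 1 nitrogen, 1 oxygen, 1 sulfur; one five-membered non-aromatic ring with 2 hetero atoms) in place of a group of 11 heavy atoms (9 carbon, 1 nitrogen, 1 sulfur; one five-membered non-aromatic ring with 2 hetero atoms, one six-membered aromatic ring of carbon only), on an amine nitrogen in a ring), but the surroundings differ: in compound 3 the place is next to the ring atom that bears a naphthalen-1-yl group and two ring bonds from the ring atom that bears a 4-bromophenyl group, whereas in compound 1 it is next to the ring atom that bears a naphthalen-2-yl group and two ring bonds from the ring atom that bears a 3,4-dimethylphenyl group. Because the earlier step was a 1.1-fold lower number from compound 1 to compound 2 (0.04 log units; within the scatter), the step expected for compound 4 is a 1.1-fold lower number from compound 3 to compound 4 (0.04 log units; within the scatter) in this assay. The estimate for compound 4 is 6000 nM, expected to lie between 2500 nM and 14000 nM.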

Compound 4, half-maximal inhibitory concentration: 5810 nM
Compound 4: middle estimate off by 1.0-fold (0.01 log units), on the high side; the range from low to high includes it.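

In this assay, putting the smaller group in place of the larger one, on the amine nitrogen in the ring, gives a 1.1-fold lower number from compound 3 to compound 4 (0.06 log units; within the scatter). On both cores the exchange leaves the number within the usual scatter, and the two steps do not differ, so the result carries over from one core to the other: the same change on two cores in this assay, a 1.1-fold lower number (0.04 log units; within the scatter) from compound 1 to compound 2 and a 1.1-fold lower number (0.06 log units; within the scatter) from compound 3 to compound 4, 1.0-fold (0.02 log units) apart, within the scatter of two such steps. For the compounds shown here, this shows only that the larger group can be exchanged for the smaller one on these two cores in this one assay, and it does not show that the same would hold on other cores or explain why the step is so small.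

The compounds shown leave open whether a different group in this place, such as an amine or a carboxylic acid, would move the number beyond the scatter. They also leave open whether the step stays this small on a core carrying a different group, such as a 4-methoxyphenyl group in place of the 4-bromophenyl group.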